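A few compounds are considered here, and "the series" means these few. Any claim that something is new, unique, unknown or untested is made for them only; others in the source may bear on it.

Working notes on the series. Compound 1 `O=C(Nc1cc(C(F)(F)F)cc(C(F)(F)F)c1)c1ccc(Sc2ccc(O)cc2)cc1` and compound 2 `O=C(Nc1cccc(S(F)(F)(F)(F)F)c1)c1ccc(Sc2ccc(O)cc2)cc1` share one core and differ only in the substituted ring on the amide nitrogen. Both have been run in a functional assay on LNCaP cells (Homo sapiens) for antiproliferative activity, read by fluorescence and propidium iodide staining, with a stated time of 96 h; on this read-out lower numbers stand for stronger inhibition and higher numbers for weaker inhibition. In this assay compound 1 gives 2390 nM. In this assay compound 2 gives 3320 nM; of the two numbers in hand this is the larger, yet the gap to compound 1 lies within the scatter, so the two compounds are not distinguished by this read-out.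

Compound 3 `O=C(Nc1cccc(C(F)(F)F)c1)c1ccc(Sc2ccc(O)cc2)cc1` is the next member to be measured in this assay. Relative to compound 2 the change is a group of 4 heavy atoms (1 carbon, 3 fluorine; no ring) in place of a group of 6 heavy atoms (5 fluorine, 1 sulfur; no ring), on an aromatic carbon. Among the compounds with values here, no measured pair isolates this change, so nothing in the data shows its size; the only guide is that compound 1 and compound 2 sit within the scatter of each other despite different groups on that ring. A step within the scatter is therefore expected, a 1.2-fold higher number from compound 2 to compound 3 (0.08 log units; within the scatter), with a slight lean toward a higher number. For compound 3 the estimate in this assay is 4000 nM, with a range from 1500 nM to 10000 nM.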

Compound 3, half-maximal inhibitory concentration: 9660 nM
Compound 3: the middle estimate sits 2.4-fold (0.38 log units) below what was measured; low and high end bracket the measured number.
By their numbers in this assay, from the lowest: compounds 1 and 2 (each within the scatter of the next); then compound 3.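

In this assay the ring on the amide nitrogen now shows that its substituents can change the read-out, which the first two compounds did not show. Trifluoromethyl in place of the group of 5 fluorine and 1 sulfur, on an aromatic carbon meta to a large group, gives a 2.9-fold higher number from compound 2 to compound 3 (0.46 log units; beyond the scatter) as a step beyond the scatter, and hydrogen in place of one trifluoromethyl on an aromatic carbon gives a 4.0-fold higher number from compound 1 to compound 3 (0.61 log units; beyond the scatter) in the same direction, so compound 3 has the weakest inhibition of the three. No measurement in hand offers an explanation for either step.

Going by these compounds, it remains open whether a group of a different kind on this ring, such as a nitrile, an amine or a carboxylic acid, would keep the number near those of compound 1 and compound 2 or move it further in either direction. On these data alone, it is also open whether these two steps would keep their size if the hydroxyl on the far side of the shared core were replaced by a methoxy group.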